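Cytotoxicity notes: hydrogen for methyl on compound 1

The source may report more compounds than this note shows. Statements on the series, on what has been measured and on what is new or still open speak of the compounds shown alone.

Going by the values given here, in an ADME assay on CCRF-CEM cells (Homo sapiens) for cytotoxicity, read by MTT assay, with a stated time of 4 days (a higher number here means that more compound is tolerated, a lower number that less compound is tolerated), compound 1 `Cc1cccc(Cc2cc(C)ccc2OCCn2ccc(=O)[nH]c2=O)c1` gives 53000 nM, the only exact reading so far, so it has no numerical neighbour to be ranked against. Compound 2 `Cc1cc(C)cc(C(=O)c2cc(Cl)ccc2OCCCn2ccc(=O)[nH]c2=O)c1` reads > 20000 nM, which is a limit of this assay and not a number.

Compound 3 `Cc1ccc(OCCn2ccc(=O)[nH]c2=O)c(Cc2ccccc2)c1` keeps the core of compound 1 and carries hydrogen in place of methyl on an aromatic carbon, which turns 3-methylbenzyl into benzyl. Among the compounds with values here, no measured pair shows what this change does, so the expectation rests on compound 1 alone at 53000 nM. No step beyond the usual scatter is expected in this assay. The expected 1.1-fold lower number from compound 1 to compound 3 (0.03 log units; within the scatter) is therefore small and without a firm direction. For compound 3 the estimated value is 50000 nM, with an expected range of 22000 nM to 100000 nM.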

Compound 3, half-maximal cytotoxic concentration in the CCRF-CEM assay: 48000 nM
Estimate against measurement, compound 3: 1.0-fold (0.02 log units) above; measured number inside the range.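

Hydrogen in place of methyl gives the first readable step in the series: in the CCRF-CEM assay it is a 1.1-fold lower number from compound 1 to compound 3 (0.04 log units; within the scatter), with compound 1 at 53000 nM and compound 3 at 48000 nM. In a physicochemical assay for solubility (a higher number here means a more soluble compound, a lower number a less soluble compound), the same change gives a 1.0-fold lower number from compound 1 to compound 3 (0.01 log units; within the scatter), with compound 1 at 36500 nM and compound 3 at 35600 nM. Neither step separates the two compounds, so 3-methylbenzyl and benzyl read alike in both assays, with the change made on an aromatic carbon meta to a large group.

Going by these compounds alone, compound 2 differs from compound 1 in more than one place and its reading is a limit of the assay, so it adds no step: the limit of > 20000 nM in the CCRF-CEM assay, at which 1 of the 3 values shown sits. From the compounds shown here alone, whether the same position tolerates a group other than methyl or hydrogen, such as an amine or a carboxylic acid, stays open, and this single pair says nothing about changes elsewhere on the shared core.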